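Swapping an aromatic ring for a non-aromatic one

The source may hold more compounds than are shown below. What is called first, only, known or untested is meant among the compounds shown, and "the series" means these compounds.

Measured in a functional assay on cells (Leukemia cell, Homo sapiens) for cytotoxicity, read by sulforhodamine B assay, with a stated time of 48 h; a higher number here means a weaker inhibitor of growth, a lower number a stronger inhibitor of growth: compound 1 `COc1ccc(OC)c(-c2cc(-c3ccccc3)nn2-c2ccc(S(=O)(=O)NC(C)=O)cc2)c1` gives 53400 nM; compound 2 `CC(=O)NS(=O)(=O)c1ccc(-n2nc(-c3ccccc3)cc2-c2cc(O)ccc2O)cc1` gives 100000 nM.

Among the measured compounds shown here, compound 2 holds the higher of the two numbers, but its only neighbour is compound 1, and the step of a 1.9-fold higher number from compound 1 to compound 2 (0.27 log units; within the scatter) lies within the scatter. Compound 3 `CC(=O)NS(=O)(=O)c1ccc(-n2nc(-c3ccccc3)cc2C2=CC(=O)C=CC2=O)cc1` differs from compound 2 by a group of 8 heavy atoms (6 carbon, 2 oxygen; one six-membered non-aromatic ring of carbon only) in place of a group of 8 heavy atoms (6 carbon, 2 oxygen; one six-membered aromatic ring of carbon only), on an aromatic carbon. For the measured compounds named here, no measured step covers this kind of change; the only known step, a 1.9-fold higher number from compound 1 to compound 2 (0.27 log units; within the scatter), altered the same group while it stayed aromatic and was within the scatter. Compound 3 is therefore expected to give about 60000 nM, in the range 15000 nM to 100000 nM. The expected step of a 1.7-fold lower number from compound 2 to compound 3 (0.22 log units; within the scatter) is estimated not to exceed the scatter.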

Compound 3, concentration for total growth inhibition: 91200 nM
Estimate against measurement, compound 3: 1.5-fold (0.18 log units) below, within the range that was stated.
By their numbers in this assay, from the lowest: compounds 1, 3 and 2 (each within the scatter of the next).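

In this assay the non-aromatic ring in place of 2,5-dihydroxyphenyl gives a 1.1-fold lower number from compound 2 to compound 3 (0.04 log units; within the scatter) and the same ring in place of 2,5-dimethoxyphenyl gives a 1.7-fold higher number from compound 1 to compound 3 (0.23 log units; within the scatter) as its step. On this aromatic carbon, next to the ring nitrogen, losing the aromatic ring therefore stays within the scatter, as the earlier change that kept the ring aromatic did. Nothing measured here offers an explanation for this result. Going by these compounds, whether an amine or a carboxylic acid on this carbon would give a step beyond the scatter remains open.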